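Swapping the benzoyl for an ester-bearing chain on the amine

This account rests on a few compounds, and the source may have more. Where it says the series, first, only, none or still open, it means among the compounds named here.

Three compounds share one core and differ only in the group on an amine nitrogen. Going by the values given here, compound 1 `CCOC(=O)NC(=O)NC1=CS(=O)(=O)O[C@@]12[C@@H](CO[Si](C)(C)C(C)(C)C)O[C@@H](n1cc(C)c(=O)n(C)c1=O)[C@@H]2O[Si](C)(C)C(C)(C)C` is the one measured as a number: in a functional assay on HEL cells (Homo sapiens) for cytotoxicity, read by microscopy (on this read-out higher numbers stand for lower toxicity in this test and lower numbers for higher toxicity in this test), compound 1 gives 16000 nM. Compound 2 `Cc1cn([C@@H]2O[C@H](CO[Si](C)(C)C(C)(C)C)[C@@]3(OS(=O)(=O)C=C3NCC(=O)OCc3ccccc3)[C@H]2O[Si](C)(C)C(C)(C)C)c(=O)n(C)c1=O` comes back only as a limit of the test, and in this assay compound 2 gives >= 400000 nM. Compound 3 `Cc1cn([C@@H]2O[C@H](CO[Si](C)(C)C(C)(C)C)[C@@]3(OS(=O)(=O)C=C3NC(=O)c3ccccc3)[C@H]2O[Si](C)(C)C(C)(C)C)c(=O)n(C)c1=O` also comes back only as a limit, and in this assay compound 3 gives >= 3200 nM, so where it truly stands is not known.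

Compound 4 `COC(=O)CCNC1=CS(=O)(=O)O[C@@]12[C@@H](CO[Si](C)(C)C(C)(C)C)O[C@@H](n1cc(C)c(=O)n(C)c1=O)[C@@H]2O[Si](C)(C)C(C)(C)C` differs from compound 3 by 2-(methoxycarbonyl)ethyl in place of benzoyl on an amine nitrogen. Of the measured steps, the closest in kind is an at least 25-fold higher number from compound 1 to compound 2 (1.39 log units; beyond the scatter), where an ester-bearing chain also replaced a carbonyl-bearing group on that nitrogen and the number moved far toward lower toxicity. The steps a step that the limit leaves unreadable from compound 1 to compound 3 and a step that the two limits leave unreadable from compound 2 to compound 3 cannot be sized, since the limit of >= 3200 nM in this assay, at which 1 of the 3 values shown sits, and the limit of >= 400000 nM in this assay, at which 1 of the 3 values shown sits, hide the true values.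

With compound 3 itself only a limit, the step to compound 4 is expected to land at or beyond that limit, toward lower toxicity, as a step that the limit leaves unreadable from compound 3 to compound 4. Compound 4 is therefore estimated at 50000 nM, within a wide range from 8000 nM to 400000 nM, and a further limit-only result is quite possible.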

Compound 4, minimum cytotoxic concentration: >= 400000 nM
Compound 4 gave a limit, no number; the forecaster's own chance of this, stated with the estimate: 40%; middle value at least 8.0-fold (0.90 log units) away from the limit.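

In this assay, compound 4 returns only a limit, >= 400000 nM, and not a number. Its 2-(methoxycarbonyl)ethyl group on the amine nitrogen still gives an at least 25-fold higher number from compound 1 to compound 4 (1.39 log units; beyond the scatter), a large move toward lower toxicity in this test, so this shift on the nitrogen is no longer seen with the (benzyloxycarbonyl)methyl group of compound 2 alone: a second ester-bearing chain, this one with no ring, gives a step of the same printed size. The steps reaching compound 4 from compound 3 and from compound 2 cannot be read, as the values at both ends are limits: the limit of >= 400000 nM in this assay, at which 2 of the 4 values shown sit.

As far as these compounds go, how far compound 2 and compound 4 truly lie beyond their shared limit stays unknown, so these two ester-bearing chains cannot be ranked against each other or against the benzoyl group of compound 3. Nor do the compounds shown tell whether the ester is needed at all, a question that a plain propyl chain on the amine nitrogen, or a carboxylic acid in place of the methyl ester of compound 4, would address.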